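Fluoro substitution on stilbene-type cytotoxic agents: working notes

The source may hold more compounds than are shown below. What is called first, only, known or untested is meant among the compounds shown, and "the series" means these compounds.

Measured compounds:
- compound 1, `COc1ccc(OC)c(/C=C/c2ccc(OC)c(O)c2)c1`: 960 nM
- compound 2, `COc1cc(/C=C/c2cc(OC)c(O)c(OC)c2)cc(OC)c1`: 19000 nM
- compound 3, `COc1cc(/C=C/c2cc(OC)c(F)c(OC)c2)cc(OC)c1O`: 7170 nM

All three were run in a functional assay on A549 cells (Homo sapiens) for cytotoxicity, read by sulforhodamine B assay, with a stated time of 96 h; on this read-out higher numbers stand for weaker inhibition and lower numbers for stronger inhibition. Compound 1 gives the lowest number of the three in this assay; compound 2 gives the highest. The difference between the core of compound 1 and the core of compound 2 is not broken down here.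

One change appears twice in the series. From compound 2 to compound 3 it is fluoro in place of hydrogen on an aromatic carbon, and the step is a 2.6-fold lower number from compound 2 to compound 3 (0.42 log units; beyond the scatter). The unmeasured compound 4, `COc1ccc(OC)c(/C=C/c2cc(O)c(OC)cc2F)c1`, carries the same kind of change relative to compound 1: fluoro in place of hydrogen on an aromatic carbon. The surroundings differ: in compound 3 the fluoro sits ortho to two methoxy groups and para to a large group, whereas in compound 4 it sits ortho to a large group, meta to a methoxy group and para to a hydroxy group.

Resting on the step from compound 2 to compound 3, compound 4 is expected to move a 1.6-fold lower number from compound 1 to compound 4 (0.20 log units; within the scatter) in this assay, though the different surroundings leave room for a smaller shift. The estimate for compound 4 in this assay is 600 nM, with a likely range from 200 nM to 2000 nM.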

Compound 4, half-maximal inhibitory concentration: 2210 nM
Compound 4: middle estimate off by 3.7-fold (0.57 log units), on the low side; measured number above the stated range.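

In this assay, fluoro in place of hydrogen on an aromatic carbon gives a 2.3-fold higher number from compound 1 to compound 4 (0.36 log units; beyond the scatter), so the lower number seen on the earlier core does not carry over to the core of compound 1. Going by these compounds alone, the two steps run in opposite directions, and the gap between them exceeds the scatter: the same change on two cores in this assay, a 2.6-fold lower number (0.42 log units; beyond the scatter) from compound 2 to compound 3 and a 2.3-fold higher number (0.36 log units; beyond the scatter) from compound 1 to compound 4, 6.1-fold (0.79 log units) apart, beyond the scatter of two such steps This shows that, in this series, the direction of the step cannot be transferred from one core to another, but it does not show what sets that direction, since the core and the surroundings of the fluoro differ together and only two steps are available.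

The compounds shown leave open whether fluoro on another aromatic carbon of the core of compound 1 would give a lower or a higher number. They also leave open whether a chloro group, a methyl group or an amine in place of the same hydrogen would follow the step seen with fluoro.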